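The compounds below may be only part of what the source reports. "The series", "measured", "known", "first", "only" and "open" are said of these compounds alone.

Measured so far:
compound 1 `CC(=O)N1CCN(c2nc(=O)c3cc(C(F)(F)F)cc([N+](=O)[O-])c3s2)CC1` — 83.9 ug/mL
compound 2 `O=C(C1CCCC1)N1CCN(c2nc(=O)c3cc(C(F)(F)F)cc([N+](=O)[O-])c3s2)CC1` — 5.34 ug/mL

Compound 2 stands at the lower of the two numbers in a physicochemical assay for solubility, read by HPLC; on this read-out lower numbers stand for lower solubility and higher numbers for higher solubility; its nearest neighbour, compound 1, lies higher, and the only shown step between them is a 16-fold lower number from compound 1 to compound 2 (1.20 log units; beyond the scatter). Compound 3 `O=C(C1CCC1)N1CCN(c2nc(=O)c3cc(C(F)(F)F)cc([N+](=O)[O-])c3s2)CC1` is not yet measured. Its change from compound 2 is cyclobutyl in place of cyclopentyl on a carbonyl carbon. Among the compounds with values here, the single measured step that bears on it is a 16-fold lower number from compound 1 to compound 2 (1.20 log units; beyond the scatter), where methyl was replaced by cyclopentyl on the same carbonyl carbon and the number fell well beyond the scatter. Cyclobutyl is a four-membered ring, between methyl and the five-membered cyclopentyl, so compound 3 is expected to land between compound 1 and compound 2, nearer compound 2. The expected step is a 2.2-fold higher number from compound 2 to compound 3 (0.35 log units; beyond the scatter), upward and modest. Compound 3 is therefore estimated at 12 ug/mL, with a range from 5 ug/mL to 30 ug/mL.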

Compound 3, solubility: 39.3 ug/mL
Estimate against measurement, compound 3: 3.3-fold (0.52 log units) below, and the stated range ends below it.
By their numbers in this assay, from the lowest: compound 2; then compound 3; then compound 1.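

In this assay, the carbonyl carbon position responds sharply to a single ring carbon: cyclobutyl in place of cyclopentyl gives a 7.4-fold higher number from compound 2 to compound 3 (0.87 log units; beyond the scatter), so ring size within the cycloalkyl amides matters and not merely the presence of a ring. Cyclobutyl in place of methyl costs far less, with a 2.1-fold lower number from compound 1 to compound 3 (0.33 log units; beyond the scatter), so most of the drop seen with cyclopentyl does not appear with cyclobutyl. Nothing available explains why the two rings differ so strongly.

Going by these compounds, it remains open where cyclopropyl would fall relative to compound 1 and compound 3, and whether cyclohexyl would read lower still than compound 2. Also open, on these data alone, is how an open chain such as isopropyl, or a ring containing oxygen such as tetrahydropyranyl, would read in this assay on the same carbonyl carbon.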